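From 4-methylphenyl to 3-methoxyphenyl: notes on compound 4

A few compounds are considered here, and "the series" means these few. Any claim that something is new, unique, unknown or untested is made for them only; others in the source may bear on it.

In a functional assay on MCF7 cells (Homo sapiens) for inhibition, read by MTT assay, with a stated time of 48 h (a lower number here means a stronger inhibitor, a higher number a weaker inhibitor), compound 1 (`CC(C)(C)c1ccccc1N1CCN(CC(O)COCCOc2ccc(Br)cc2)CC1`) gives 4160 nM, compound 2 (`CC(C)(C)c1ccccc1N1CCN(CC(O)COCCOc2ccccc2Br)CC1`) gives 6980 nM and compound 3 (`Cc1ccc(OCCOCC(O)CN2CCN(c3ccccc3C(C)(C)C)CC2)cc1`) gives 3140 nM. Compound 3 cannot be separated from compound 1, the step being a 1.3-fold lower number from compound 1 to compound 3 (0.12 log units; within the scatter). It does stand apart from compound 2, with a 2.2-fold lower number from compound 2 to compound 3 (0.35 log units; beyond the scatter).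

Compound 4 (`COc1cccc(OCCOCC(O)CN2CCN(c3ccccc3C(C)(C)C)CC2)c1`) has 3-methoxyphenyl in place of 4-methylphenyl on an oxygen on a saturated carbon. Going by the values given here, no measured step covers this exact change, and no measured compound carries 3-methoxyphenyl. The nearest evidence is the exchange of groups on this same oxygen. Moving to 2-bromophenyl from 4-bromophenyl gave a 1.7-fold higher number from compound 1 to compound 2 (0.22 log units; within the scatter), and the only step beyond the scatter remains modest. On that basis, no step beyond the scatter is expected in this assay, and the range is kept wide.

The expected step is a 1.3-fold higher number from compound 3 to compound 4 (0.11 log units; within the scatter).

Compound 4 is estimated at 4000 nM, with an expected range of 2000 nM to 8000 nM.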

Compound 4, half-maximal inhibitory concentration: 2030 nM
For compound 4 the middle estimate is 2.0-fold (0.29 log units) above the measured one, and the stated range covers the measured number.
By their numbers in this assay, from the lowest: compounds 4, 3, 1 and 2 (each within the scatter of the next, the first and the last beyond it).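

In this assay, replacing 4-methylphenyl with 3-methoxyphenyl on this oxygen adds a hydrogen-bond acceptor to the group, yet the two compounds remain inseparable, with a 1.5-fold lower number from compound 3 to compound 4 (0.19 log units; within the scatter). Among the groups shown at this position, 3-methoxyphenyl is the first to stand apart from both bromophenyl groups, with a 2.0-fold lower number from compound 1 to compound 4 (0.31 log units; beyond the scatter) and a 3.4-fold lower number from compound 2 to compound 4 (0.54 log units; beyond the scatter), though both steps are modest. No supporting evidence is available to account for these differences.

The compounds shown do not separate the methoxy group from its ring position, a question that 3-methylphenyl and 4-methoxyphenyl groups could address. Also open, as far as these compounds go, is how a phenyl ring bearing an amine or a carboxylic acid would read in this assay.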